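Branching the chain: propyl to isopropyl and cytotoxicity

The compounds below may be only part of what the source reports. "The series", "measured", "known", "first", "only" and "open" are said of these compounds alone.

Compound 1 `CCN(c1ccnc(Nc2ccc(C#N)cc2)n1)c1c(F)cc(-c2ccc(C#N)cc2)cc1F`: 105000 nM
Compound 2 `CCCN(c1ccnc(Nc2ccc(C#N)cc2)n1)c1c(F)cc(-c2ccc(C#N)cc2)cc1F`: 212000 nM

In an ADME assay on MT4 cells (Homo sapiens) for cytotoxicity, read by MTT assay, with a stated time of 5 days (on this read-out higher numbers stand for lower toxicity in this test and lower numbers for higher toxicity in this test), compound 2 gives 212000 nM, the highest of the two numbers; compound 1 gives 105000 nM. The step of a 2.0-fold higher number from compound 1 to compound 2 (0.31 log units; beyond the scatter) lengthens the chain. Compound 3 `CC(C)N(c1ccnc(Nc2ccc(C#N)cc2)n1)c1c(F)cc(-c2ccc(C#N)cc2)cc1F` instead rearranges it: isopropyl in place of propyl on a nitrogen on an aromatic ring. Within the data shown here, no measured step pairs two chains of equal length joined differently, so that step gives only weak guidance. The expected step of a 1.1-fold lower number from compound 2 to compound 3 (0.03 log units; within the scatter) is therefore none beyond the scatter. Compound 3 is estimated at 200000 nM, within 100000 nM to 400000 nM.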

Compound 3, half-maximal cytotoxic concentration: 172000 nM
The estimate for compound 3 lay 1.2-fold (0.07 log units) above the measured number; the measured number falls inside the stated range.
By their numbers in this assay, from the lowest: compounds 1, 3 and 2 (each within the scatter of the next, the first and the last beyond it).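

In this assay, joining the same three carbons as isopropyl rather than propyl on this nitrogen gives a 1.2-fold lower number from compound 2 to compound 3 (0.09 log units; within the scatter) and so shows that the change of shape has no effect beyond the scatter here. The step is a 1.6-fold higher number from compound 1 to compound 3 (0.21 log units; within the scatter) and so compound 3 does not stand clearly apart from compound 1, whereas compound 2 does. Nothing measured here explains these numbers. On these data alone, whether a longer chain such as butyl, a cyclopropyl ring or a chain carrying an amine would behave the same way remains open.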